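Swapping the Aryl Group on the Exocyclic Double Bond

A few compounds are considered here, and "the series" means these few. Any claim that something is new, unique, unknown or untested is made for them only; others in the source may bear on it.

Three compounds share one core and differ only in the aromatic group on a double-bonded chain carbon bound to a double-bonded ring carbon. Compound 1 `O=C1N=C(N2CCC[C@H]2C(=O)Nc2ccc3ncnc(Nc4cccc(Cl)c4)c3c2)S/C1=C/c1cccc(Br)n1` carries a 6-bromopyridin-2-yl group there, and in a functional assay on A549 cells (Homo sapiens) for antiproliferative activity, read by MTT assay (a lower number here means a stronger inhibitor, a higher number a weaker inhibitor), compound 1 gives 3100 nM. Compound 2 `O=C1N=C(N2CCC[C@H]2C(=O)Nc2ccc3ncnc(Nc4cccc(Cl)c4)c3c2)S/C1=C/c1ccccc1[N+](=O)[O-]` carries a 2-nitrophenyl group, and in this assay compound 2 reaches only a limit of the assay, > 50000 nM, not a number. Compound 3 `O=C1N=C(N2CCC[C@H]2C(=O)Nc2ccc3ncnc(Nc4cccc(Cl)c4)c3c2)S/C1=C/c1cccc(Br)c1` carries a 3-bromophenyl group, and in this assay compound 3 likewise stops at a limit, > 50000 nM. Compound 2 therefore stands at the weak end of what is shown, at the limit of > 50000 nM in this assay, at which 2 of the 3 values shown sit. Both steps away from the pyridyl compound are large: an at least 16-fold higher number from compound 1 to compound 2 (1.20 log units; beyond the scatter) and an at least 16-fold higher number from compound 1 to compound 3 (1.20 log units; beyond the scatter). Between the two limits, a step that the two limits leave unreadable from compound 2 to compound 3.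

Compound 4 `O=C1N=C(N2CCC[C@H]2C(=O)Nc2ccc3ncnc(Nc4cccc(Cl)c4)c3c2)S/C1=C/c1ccc(-c2ccccc2)cc1` is not yet measured. 4-phenylphenyl in place of 2-nitrophenyl on a double-bonded chain carbon bound to a double-bonded ring carbon The expectation for it rests on an at least 16-fold higher number from compound 1 to compound 2 (1.20 log units; beyond the scatter) and an at least 16-fold higher number from compound 1 to compound 3 (1.20 log units; beyond the scatter), each of which carried a carbon-only aryl group to the limit. Compound 4, with a third carbon-only aryl group, is expected to sit near that limit as well. The step of an at least 1.2-fold lower number from compound 2 to compound 4 (0.09 log units; that floor lies within the scatter) is expected to stay within the scatter. For compound 4 the estimate is 40000 nM, within 8000 nM to 100000 nM, with a fair chance that only a limit is reported.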

Compound 4, half-maximal inhibitory concentration: 24200 nM
Beside the measured number, compound 4's estimate is 1.7-fold (0.22 log units) above it; the measured number falls inside the stated range.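

Among the compounds shown here, compound 4 is the first carbon-only aryl group at this position to give a number rather than a limit in this assay, with an at least 2.0-fold lower number from compound 2 to compound 4 (0.31 log units; beyond the scatter) and an at least 2.0-fold lower number from compound 3 to compound 4 (0.31 log units; beyond the scatter), so a measurable value here does not need a ring nitrogen like the one in the 6-bromopyridin-2-yl group. Still, the strongest of the four remains the compound with the 6-bromopyridin-2-yl group, with a 7.8-fold higher number from compound 1 to compound 4 (0.89 log units; beyond the scatter). A carbon-only aryl group gives no assurance of a number either, as compound 2 and compound 3 go against any such rule and stay at a limit: the limit of > 50000 nM in this assay, at which 2 of the 4 values shown sit.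

What the compounds shown leave open is how much of the lead of compound 1 belongs to its ring nitrogen and how much to its bromine, a question that an unsubstituted pyridin-2-yl group would help to separate. They also leave open whether a ring nitrogen would add to the value of compound 4, as a 4-(pyridin-2-yl)phenyl group could test, and whether an amine on the aryl ring, such as in a 4-aminophenyl group, would be any better.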